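The source may report more compounds than this note shows. Statements on the series, on what has been measured and on what is new or still open speak of the compounds shown alone.

In a functional assay on PC-3 cells (Homo sapiens) for cytotoxicity, read by sulforhodamine B assay, with a stated time of 72 h (on this read-out higher numbers stand for weaker inhibition of growth and lower numbers for stronger inhibition of growth), compound 2 `CC(=O)N1c2ccccc2CCC1C(=O)Nc1ccccc1O` gives 70700 nM, the highest of the two numbers at hand. Among the compounds with values here, its nearest neighbour is compound 1 `O=C(Nc1cc(C(F)(F)F)cc(C(F)(F)F)c1)C1CCc2ccccc2N1C(=O)c1ccccc1Cl`, which in this assay gives 8040 nM, a gap that lies beyond the scatter of the method; compound 1 and compound 2 differ in more than one place, so their two values show only that compound 1 sits well below compound 2. Compound 3 `O=C(Nc1ccccc1O)C1CCc2ccccc2N1C(=O)c1ccccc1Cl` is reached from compound 2 by a single change, (2-chlorophenyl in place of methyl on a carbonyl carbon). Within the data shown here, no measured pair covers this exact change. Among the measured compounds shown here, compound 1, the one compound here carrying the (2-chlorophenyl)carbonyl group, gives 8040 nM, and on that ground compound 3 is expected to move toward lower numbers. The step from compound 2 to compound 3 is expected to be a 4.7-fold lower number from compound 2 to compound 3 (0.67 log units; beyond the scatter), beyond the scatter. Compound 3 is therefore estimated at 15000 nM, with a range from 5000 nM to 45000 nM.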

Compound 3, concentration for 50% growth inhibition: 60000 nM
The estimate for compound 3 lay 4.0-fold (0.60 log units) below the measured number; the measured number lies above the stated range.
By their numbers in this assay, from the lowest: compound 1; then compounds 3 and 2 (each within the scatter of the next).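

In this assay, 2-chlorophenyl in place of methyl on a carbonyl carbon, whose other neighbour is an amide-type nitrogen in a ring, gives a 1.2-fold lower number from compound 2 to compound 3 (0.07 log units; within the scatter), so this larger aromatic group leaves the number where it was. The (2-chlorophenyl)carbonyl group alone thus does not go with the lower number of compound 1: compound 3 carries the same group and gives 60000 nM, while compound 1 gives 8040 nM, and the two differ in the group on the other amide nitrogen. Nothing at hand explains why this change leaves the number in place.

The compounds shown leave open whether an amine or a longer alkyl chain on this carbonyl carbon would move the number. They also leave open whether acetyl in place of (2-chlorophenyl)carbonyl would matter in the setting of compound 1.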